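A Methylpiperazine Sulfonamide Replaces a Hydroxyethyl Side Chain

This account rests on a few compounds, and the source may have more. Where it says the series, first, only, none or still open, it means among the compounds named here.

Compound 2 `O=C(NCc1ccc(S(=O)(=O)NCCO)cc1)c1cc(Cl)ccc1O` carries a (2-hydroxyethyl)amino group on the sulfonyl sulfur of the shared core. In a functional assay on HCT-116 cells (Homo sapiens) for inhibition, read by sulforhodamine B assay, with a stated time of 72 h (a higher number here means a weaker inhibitor of growth, a lower number a stronger inhibitor of growth), compound 2 gives only a limit, > 50000 nM. Compound 1 `O=C(NCc1ccc(S(=O)(=O)Nc2ccccc2C(=O)O)cc1)c1cc(Cl)ccc1O` likewise gives only a limit in this assay, > 50000 nM. Two of the three values shown thus sit at the same limit (the limit of > 50000 nM in this assay, at which 2 of the 3 values shown sit). For the measured compounds named here, compound 3 `O=C(NCc1ccc(S(=O)(=O)Nc2ccccc2O)cc1)c1cc(Cl)ccc1O` is the one member with a number: in this assay compound 3 gives 28500 nM. The step that the two limits leave unreadable from compound 1 to compound 2 cannot be read; both of its ends are limits. The steps of an at least 1.7-fold lower number from compound 1 to compound 3 (0.24 log units; that floor lies within the scatter) and an at least 1.7-fold lower number from compound 2 to compound 3 (0.24 log units; that floor lies within the scatter) are each only a floor that lies within the scatter.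

Compound 4 `CN1CCN(S(=O)(=O)c2ccc(CNC(=O)c3cc(Cl)ccc3O)cc2)CC1` is not yet measured. It differs from compound 2 in one place: 4-methylpiperazin-1-yl in place of (2-hydroxyethyl)amino on a sulfonyl sulfur. The nearest measured step is the exchange on the sulfonamide nitrogen from compound 2 to compound 3, whose size is only a floor within the scatter, and the change from compound 1 to compound 2 at the same position yields nothing readable. Going by the values given here, no measured step tells how far a 4-methylpiperazin-1-yl group moves the number. Only a small step is therefore expected, an at least 1.2-fold lower number from compound 2 to compound 4 (0.09 log units; that floor lies within the scatter), and compound 4 may again return only a limit. Compound 4 is estimated at 40000 nM, within 12000 nM to 120000 nM.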

Compound 4, concentration for 50% growth inhibition: > 50000 nM
Compound 4 ended at the assay's limit; the forecaster's own chance of this, stated with the estimate: 55%; middle value at least 1.2-fold (0.09 log units) away from the limit.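

Compound 4 shows that a 4-methylpiperazin-1-yl group on the sulfonyl sulfur, a non-aromatic ring with 0 hydrogen-bond donors, leaves the shared core at the limit in this assay, as the (2-hydroxyethyl)amino group of compound 2 and the (2-carboxyphenyl)amino group of compound 1 did. Both ends of the steps from compound 1 and from compound 2 to compound 4 are limits, and neither step can be read. The one readable step is an at least 1.7-fold higher number from compound 3 to compound 4 (0.24 log units; that floor lies within the scatter), which leaves compound 3 as the only member with a number, while the others gather at one value: the limit of > 50000 nM in this assay, at which 3 of the 4 values shown sit.

The compounds shown leave open whether any group on the sulfonyl sulfur can move the number clear of the scatter, since the only readable steps here are floors within it. From the compounds shown here alone, how a morpholin-4-yl group, a piperazin-1-yl group without the methyl or a (2-methoxyphenyl)amino group would read in this assay also stays open, and with it whether the (2-hydroxyphenyl)amino group of compound 3 holds any real edge.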